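This account rests on a few compounds, and the source may have more. Where it says the series, first, only, none or still open, it means among the compounds named here.

Measured so far in an assay on MDA-MB-231 cells for displacement of a labelled ligand from C-X-C chemokine receptor type 4 (Homo sapiens), read by fluorescence and microscopy, with stated times of 10 min and 30 min; a lower number here means that less compound is needed, a higher number that more compound is needed for the effect:
Compound 1 `O=C(NCc1ccc(CNS(=O)(=O)c2ccccc2F)cc1)c1cccnc1` gives 100 nM
Compound 2 `O=C(NCc1ccc(CNS(=O)(=O)c2ccc([N+](=O)[O-])cc2)cc1)c1cccnc1` gives 100 nM

Compound 2 stands level with compound 1 at the digits shown; the only step so far, no change at the digits printed from compound 1 to compound 2 (within the scatter), swapped one aryl group on the sulfonyl sulfur without effect beyond the scatter. Compound 3 `O=C(NCc1ccc(CNS(=O)(=O)c2cccc3ccccc23)cc1)c1cccnc1` carries the same change in a different direction: naphthalen-1-yl in place of 4-nitrophenyl on a sulfonyl sulfur. For the measured compounds named here, with only that flat step to go on, another change at the same sulfonyl sulfur is expected to leave this assay roughly unchanged. Compound 3 is therefore estimated at 100 nM, with a range from 35 nM to 300 nM. That expected step is no change at the digits printed from compound 2 to compound 3 (within the scatter).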

Compound 3, effective concentration (reported as EC, without a stated level of effect): 1000 nM
Compound 3: middle estimate off by 10-fold (1.00 log units), on the low side; the measured number lies above the stated range.
By their numbers in this assay, from the lowest: compounds 1 and 2 (each within the scatter of the next); then compound 3.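

In this assay this sulfonyl position does not treat all aryl groups alike: naphthalen-1-yl gives a 10-fold higher number from compound 2 to compound 3 (1.00 log units; beyond the scatter) and a 10-fold higher number from compound 1 to compound 3 (1.00 log units; beyond the scatter) while the swap between 2-fluorophenyl and 4-nitrophenyl moved nothing beyond the scatter. The number therefore does respond to what sits on this sulfur, and among these compounds only the group with two rings raises it. Nothing available explains this step. On these data alone, whether naphthalen-2-yl would behave like naphthalen-1-yl stays open. So does what a plain phenyl, a methyl or a benzyl group would give on the same sulfur.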